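This account rests on a few compounds, and the source may have more. Where it says the series, first, only, none or still open, it means among the compounds named here.

Two compounds of the series have numbers in an assay on membranes from liver for displacement of a labelled ligand from Sigma intracellular receptor 2 (Rattus norvegicus), read by scintillation counting, with a stated time of 120 min (a higher number here means a weaker inhibitor, a lower number a stronger inhibitor), so far. Compound 1 `Cc1cccc2sc(NC(=O)CCN3CCN(C(C)C)CC3)nc12` gives 1800 nM, and compound 2 `Cc1cccc2sc(NC(=O)CCN3CCN(CC4CCCO4)CC3)nc12` gives 5000 nM. Compound 2 therefore stands at the highest of the two numbers, and the step of a 2.8-fold higher number from compound 1 to compound 2 (0.44 log units; beyond the scatter) is modest but beyond the scatter. Compound 3 `Cc1cccc2sc(NC(=O)CCN3CCN(C4CCCCC4)CC3)nc12` is not yet measured. It differs from compound 2 in one place: cyclohexyl in place of (oxolan-2-yl)methyl on an amine nitrogen in a ring. Among the compounds with values here, the only measured step that bears on this change is a 2.8-fold higher number from compound 1 to compound 2 (0.44 log units; beyond the scatter), since it alters the same group on the same ring nitrogen. The isopropyl of compound 1 and the cyclohexyl of compound 3 are both groups of carbon only, whereas the (oxolan-2-yl)methyl of compound 2 carries an oxygen, so the new change runs roughly opposite to the one already measured, and that single step sets a modest size for changes at this place. Compound 3 is therefore expected to give a modest decrease of about a 2.8-fold lower number from compound 2 to compound 3 (0.44 log units; beyond the scatter), back toward the lower of the two measured numbers. The estimate for compound 3 is 1800 nM, with a range from 600 nM to 5500 nM.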

Compound 3, inhibition constant: 233 nM
Estimate against measurement, compound 3: 7.7-fold (0.89 log units) above, and the stated range ends above it.
By their numbers in this assay, from the lowest: compound 3; then compound 1; then compound 2.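

In this assay, within the data shown here, this place on the ring nitrogen has a wider span than the single earlier step indicated: cyclohexyl in place of (oxolan-2-yl)methyl gives a 21-fold lower number from compound 2 to compound 3 (1.33 log units; beyond the scatter), a large step set against the modest 2.8-fold higher number from compound 1 to compound 2 (0.44 log units; beyond the scatter). The carbon-only groups do not behave alike either, since cyclohexyl in place of isopropyl gives a 7.7-fold lower number from compound 1 to compound 3 (0.89 log units; beyond the scatter), so the absence of the oxygen does not by itself set the number, and compound 3 is the lowest of the three, with both of its steps beyond the scatter. Nothing available explains why this change has so large an effect.

The three compounds do not separate the ring from the link and the oxygen: a cyclohexylmethyl group would show what the one-carbon link does with an all-carbon ring, and an oxan-4-yl group would show what a ring oxygen does with no link. As far as these compounds go, whether the lower number extends to a cyclopentyl or a phenyl group on the same nitrogen also remains open.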